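A few compounds are considered here, and "the series" means these few. Any claim that something is new, unique, unknown or untested is made for them only; others in the source may bear on it.

Working notes on the series, all read in a functional assay on MCF7 cells (Homo sapiens) for cytotoxicity, read by MTT assay, with a stated time of 96 h; a lower number here means a stronger inhibitor, a higher number a weaker inhibitor. Compound 3 (`COc1cc(C(=O)c2cn(-c3ccccc3)cc2-c2ccccc2Cl)cc(OC)c1OC`) gives 76 nM, compound 1 (`COc1cc(C(=O)c2cn(-c3cccc(Br)c3)cc2-c2ccccc2)cc(OC)c1OC`) gives 78 nM and compound 2 (`COc1cc(C(=O)c2cn(-c3ccc(Cl)cc3)cc2-c2ccccc2)cc(OC)c1OC`) gives 140 nM. All three values lie within the scatter of one another, so compound 3 stands level with both. The change to compound 4 (`COc1cc(C(=O)c2cn(-c3ccccc3)cc2-c2cccc(Br)c2)cc(OC)c1OC`) is 3-bromophenyl in place of 2-chlorophenyl on an aromatic carbon, next to the ring atom that bears a large group.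

Among the compounds with values here, the one measured step, a 1.8-fold higher number from compound 1 to compound 2 (0.25 log units; within the scatter), lies on an aromatic nitrogen, not at this carbon, and stays within the scatter. It bears on the change only indirectly. Compound 1 carries the same 3-bromophenyl on that nitrogen and gives 78 nM. Within the data shown here, no measured step covers a change at this carbon, so no direction can be drawn from the data, and no shift beyond the scatter is expected in this assay. The estimated step is a 1.3-fold higher number from compound 3 to compound 4 (0.12 log units; within the scatter). For compound 4 the expected value is 100 nM, with an estimated range of 35 nM to 300 nM.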

Compound 4, half-maximal inhibitory concentration: 950 nM
Beside the measured number, compound 4's estimate is 9.5-fold (0.98 log units) below it; measured number outside the range, above it.
By their numbers in this assay, from the lowest: compounds 3, 1 and 2 (each within the scatter of the next); then compound 4.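

In this assay, within the data shown here, the exchange of 2-chlorophenyl for 3-bromophenyl at this aromatic carbon gives a 13-fold higher number from compound 3 to compound 4 (1.10 log units; beyond the scatter) and is the only step so far that lies beyond the scatter, so this position responds to the substituted phenyl it carries in a way the step on the aromatic nitrogen did not show. The two groups have the same count of heavy atoms, and neither has a hydrogen-bond donor, a hydrogen-bond acceptor or a net charge, so these counts do not separate them; the halogen and its place on the phenyl ring change together. No measured evidence in hand accounts for the size of this step.

The compounds shown leave open whether the halogen or its place on the ring carries the step, which 3-chlorophenyl or 2-bromophenyl at this carbon would separate. Also open, as far as these compounds go, is how an amine or a carboxylic acid on this phenyl ring would read in this assay.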